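Swapping Nitrile for Trifluoromethyl on a Weak Inhibitor

The source may hold more compounds than are shown below. What is called first, only, known or untested is meant among the compounds shown, and "the series" means these compounds.

Compound 1 `CC(C)Oc1nc(N)nc2ncc(-c3ccc(C#N)cc3)nc12`: > 10000 nM
Compound 2 `COc1ccc(-c2cnc3nc(N)nc(N4CCN(Cc5ccccc5F)CC4)c3n2)cc1OC`: 700 nM
Compound 3 `COc1ccc(-c2cnc3nc(N)nc(N4CCN(C(=O)Nc5cccc(C)c5)CC4)c3n2)cc1OC`: 7 nM

Three compounds share a core and were tested in a functional assay on cells (T-cell, Homo sapiens) for inhibition; on this read-out higher numbers stand for weaker inhibition and lower numbers for stronger inhibition. Compound 1 is the weakest of the three, and its value is not a number but a limit of the assay: it sits at the limit of > 10000 nM in this assay, at which 1 of the 3 values shown sits. Compound 2 gives 700 nM in this assay, while compound 3 gives 7 nM, a far stronger inhibition.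

For the measured compounds named here, the only measured step, a 100-fold lower number from compound 2 to compound 3 (2.00 log units; beyond the scatter), changes a group on a ring nitrogen away from the part of the core considered here, so it gives no guide for the change from compound 1 to compound 4.

Compound 4 `CC(C)Oc1nc(N)nc2ncc(-c3ccc(C(F)(F)F)cc3)nc12` differs from compound 1 by trifluoromethyl in place of cyano on an aromatic carbon. Nothing measured bears on this change, so no movement beyond the scatter is expected, and compound 1 itself only reached the limit. For compound 4 the expected outcome is a value around 12000 nM, estimated between 3000 nM and 40000 nM. The step that the limit leaves unreadable from compound 1 to compound 4 is thus expected to be flat, most likely with the assay again returning only a limit.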

Compound 4, half-maximal inhibitory concentration: > 10000 nM
Compound 4 was reported as a limit (the forecaster's own chance of this, stated with the estimate: 70%); the middle value is on the limit's open side.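

Compound 1 and compound 4 both return a limit rather than a number, so no step between them can be read: the limit of > 10000 nM in this assay, at which 2 of the 4 values shown sit.

As far as these compounds go, whether trifluoromethyl in place of cyano on this scaffold changes inhibition at all, and in which direction, remains open.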